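From methoxy to hydroxy in compound 3

The compounds below may be only part of what the source reports. "The series", "measured", "known", "first", "only" and "open" are said of these compounds alone.

In a functional assay on SW-620 cells (Homo sapiens) for cytotoxicity, read by MTT assay, with a stated time of 72 h (on this read-out higher numbers stand for weaker inhibition and lower numbers for stronger inhibition), compound 1 (`COc1ccc(/C=C2\CCC/C(=C\c3ccccc3Br)C2=O)cc1OC`) gives 5300 nM and compound 2 (`COc1ccc(/C=C2\CCC/C(=C\c3ccc(Br)cc3)C2=O)cc1OC`) gives 5200 nM while compound 3 (`COc1cccc(/C=C2\CCC/C(=C\c3ccc(OC)c(OC)c3)C2=O)c1`) gives 3700 nM in the same range. These numbers lie within the scatter of one another, so compound 3 stands level with both. Compound 4 (`COc1ccc(/C=C2\CCC/C(=C\c3cccc(O)c3)C2=O)cc1OC`) follows from compound 3 through hydrogen in place of methyl on an oxygen on an aromatic ring as 3-methoxyphenyl becomes 3-hydroxyphenyl. Going by the values given here, no measured compound carries this hydroxy group, so the evidence is indirect. Exchanges at the same place give a 1.4-fold lower number from compound 1 to compound 3 (0.16 log units; within the scatter) and a 1.4-fold lower number from compound 2 to compound 3 (0.15 log units; within the scatter) as the closest guides, alongside a 1.0-fold lower number from compound 1 to compound 2 (0.01 log units; within the scatter) as well. The expected step is therefore a 1.1-fold lower number from compound 3 to compound 4 (0.04 log units; within the scatter) and nothing beyond the scatter. Compound 4 is estimated at 3400 nM with 1500 nM to 7500 nM as its expected range.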

Compound 4, half-maximal inhibitory concentration: 1900 nM
Estimate against measurement, compound 4: 1.8-fold (0.25 log units) above; the measured number falls inside the stated range.
By their numbers in this assay, from the lowest: compounds 4, 3, 2 and 1 (each within the scatter of the next, the first and the last beyond it).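

In this assay the exchange of methoxy for hydroxy stays within the scatter (see a 1.9-fold lower number from compound 3 to compound 4 (0.29 log units; within the scatter)), so compound 4 stands level with compound 3. Going by these compounds alone, the 3-hydroxyphenyl group nevertheless gives the first steps in this set that pass beyond the scatter, though only modestly (see a 2.7-fold lower number from compound 2 to compound 4 (0.44 log units; beyond the scatter) and a 2.8-fold lower number from compound 1 to compound 4 (0.45 log units; beyond the scatter)). Nothing measured here explains these steps. The compounds shown leave open whether an amine or a carboxylic acid in place of the hydroxy group would hold these numbers. They also leave open how a longer chain on that oxygen would read.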